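A few compounds are considered here, and "the series" means these few. Any claim that something is new, unique, unknown or untested is made for them only; others in the source may bear on it.

In a functional assay on MIA PaCa-2 cells (Homo sapiens) for antiproliferative activity, read by MTT assay, with a stated time of 3 days (on this read-out higher numbers stand for weaker inhibition and lower numbers for stronger inhibition), compound 1 (`O=C1c2ccccc2C(=O)N1C/C=C\Cn1cc(C#Cc2ccc(Br)cc2)c(=O)[nH]c1=O`) gives > 100000 nM, which is a limit and not a number, and it stands with the limit of > 100000 nM in this assay, at which 2 of the 3 values shown sit. Compound 3 (`CCCCCCCCC#Cc1cn(C/C=C/CN2C(=O)c3ccccc3C2=O)c(=O)[nH]c1=O`) gives > 100000 nM, also a limit. Among the measured compounds shown here, compound 2 (`CCCCCCC#Cc1cn(C/C=C/CN2C(=O)c3ccccc3C2=O)c(=O)[nH]c1=O`) gives 30000 nM, the only true number so far. Compound 4 (`CCCCC#Cc1cn(C/C=C\CN2C(=O)c3ccccc3C2=O)c(=O)[nH]c1=O`) differs from compound 1 by butyl in place of 4-bromophenyl on a triple-bonded carbon, with butyl in place of 4-bromophenyl on a triple-bonded carbon. For the measured compounds named here, the one measured step bearing on this is an at least 3.3-fold higher number from compound 2 to compound 3 (0.52 log units; beyond the scatter), where ethyl added to the saturated chain goes with weaker inhibition. It concerns chain size only, so a modest move towards stronger inhibition is expected, with a real chance of another limit. The expected step is an at least 2.2-fold lower number from compound 1 to compound 4 (0.34 log units; beyond the scatter). For compound 4 the estimated value is 45000 nM, with an expected range of 15000 nM to 100000 nM.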

Compound 4, half-maximal inhibitory concentration: > 100000 nM
Compound 4 ended at the assay's limit; the forecaster's own chance of this, stated with the estimate: 40%; middle value at least 2.2-fold (0.34 log units) from the limit.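

In this assay compound 1 and compound 4 both end at a limit, so butyl in place of 4-bromophenyl gives no readable step: the limit of > 100000 nM in this assay, at which 3 of the 4 values shown sit.

Which of these two groups on the triple-bonded carbon goes with stronger inhibition stays open.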